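The compounds below may be only part of what the source reports. "The series", "measured", "known", "first", "only" and "open" are said of these compounds alone.

Of the compounds shown here, three that share one core have been tested in a functional assay on MCF7 cells (Homo sapiens) for antiproliferative activity, read by MTT assay, with a stated time of 72 h; on this read-out lower numbers stand for stronger inhibition and higher numbers for weaker inhibition. Compound 1, `O=C1O/C(=C\Cn2cc(-c3ccc(Br)cc3)nn2)C(OCc2ccccc2)=C1OCc1ccccc1`, carries a 4-bromophenyl group on a five-membered aromatic ring with three nitrogens. In this assay compound 1 gives > 100000 nM, a limit of the assay rather than a number. Compound 2, `O=C1O/C(=C\Cn2cc(-c3cc(F)cc(F)c3)nn2)C(OCc2ccccc2)=C1OCc1ccccc1`, differs from it by a 3,5-difluorophenyl in place of 4-bromophenyl on an aromatic carbon. In this assay compound 2 gives > 100000 nM, again a limit. The step that the two limits leave unreadable from compound 1 to compound 2 therefore cannot be read. Compound 3, `CC(C)(C)OC(=O)N1CCN(C(=S)SCc2cn(C[C@H](O)[C@H]3OC(=O)C(OCc4ccccc4)=C3OCc3ccccc3)nn2)CC1`, keeps the core with a different side chain. In this assay compound 3 gives > 100000 nM, also a limit. All values shown sit at the limit of > 100000 nM in this assay, at which 3 of the 3 values shown sit, and compound 2 stands there with the others.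

Compound 4, `COc1ccccc1-c1cn(C/C=C2\OC(=O)C(OCc3ccccc3)=C2OCc2ccccc2)nn1`, differs from compound 2 by 2-methoxyphenyl in place of 3,5-difluorophenyl on an aromatic carbon. Among the compounds with values here, the only measured step, from compound 1 to compound 2, is unreadable, so no measured step sets a size for this change. Compound 4 is therefore expected to give 100000 nM in this assay, with a range from 30000 nM to 300000 nM. The step of a number no higher from compound 2 to compound 4 (the limit leaves the size open) is expected to be no change beyond the scatter.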

Compound 4, half-maximal inhibitory concentration: > 100000 nM
Compound 4: a limit, no number; the forecaster's own chance of this, stated with the estimate: 75%; the middle value sits exactly at the limit.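

The comparisons of compound 4 with compound 1 and with compound 2 give no readable step: each pairs two limits of the assay, not two numbers. How strongly any of these compounds inhibits stays open, for all stand at one point: the limit of > 100000 nM in this assay, at which 4 of the 4 values shown sit.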